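From Diethylamino to Dipropylamino on a Shared Core

This account rests on a few compounds, and the source may have more. Where it says the series, first, only, none or still open, it means among the compounds named here.

Of the compounds shown here, three with the same core have been tested in an ADME assay on MT4 cells (Homo sapiens) for cytotoxicity, read by MTT assay, with a stated time of 4 days; on this read-out higher numbers stand for lower toxicity in this test and lower numbers for higher toxicity in this test. Compound 1, `CC(C)N(C)c1nc(Cc2c(F)cccc2F)cc(=O)[nH]1`, gives 85000 nM, and compound 2, `CCCN(C)c1nc(Cc2c(F)cccc2F)cc(=O)[nH]1`, gives 85000 nM.

Compound 3, `CCN(CC)c1nc(Cc2c(F)cccc2F)cc(=O)[nH]1`, reads > 85000 nM, which is a limit of the assay and not a number. From the compounds shown here alone, its exact place among the three therefore remains unknown.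

Compound 4, `CCCN(CCC)c1nc(Cc2c(F)cccc2F)cc(=O)[nH]1`, has not yet been measured. It differs from compound 3 in one place: dipropylamino in place of diethylamino on an aromatic carbon. Dipropylamino takes the place of diethylamino on an aromatic carbon, between two ring nitrogen atoms.

Three measured steps offer guidance, all indirect, since none lengthens both chains on the nitrogen in this way. Putting propyl in place of isopropyl gave no change at the digits printed from compound 1 to compound 2 (within the scatter). The two steps that introduce diethylamino are a number no lower from compound 1 to compound 3 (the limit leaves the size open) and a number no lower from compound 2 to compound 3 (the limit leaves the size open), and their size cannot be read. Going by the values given here, the only readable step is thus flat, so no shift beyond the usual scatter is expected in this assay, though the starting point is only a limit.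

The expected result is a number no higher from compound 3 to compound 4 (the limit leaves the size open). For compound 4, the estimated value is 85000 nM, with an expected range from 40000 nM to 170000 nM.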

Compound 4, half-maximal cytotoxic concentration: > 78000 nM
Compound 4 ended at the assay's limit; the forecaster's own chance of this, stated with the estimate: 50%; the middle value does not contradict the limit.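

In this assay, compound 4 reads > 78000 nM, which is a limit of the assay and not a number, so its steps from compound 1, compound 2 and compound 3 cannot be read. The compounds shown leave open whether dipropylamino in place of diethylamino changes the read-out in this assay at all.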